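The compounds below may be only part of what the source reports. "The series", "measured", "known", "first", "only" and "open" are said of these compounds alone.

In a physicochemical assay for solubility, in phosphate buffer, at pH 6.5 (on this read-out lower numbers stand for lower solubility and higher numbers for higher solubility), compound 2 `C=C[C@@H]1C[C@]1(NC(=O)[C@@H]1C[C@@H](Oc2nccc3cc(OC)ccc23)CN1C(=O)[C@@H](NC(=O)N[C@H](COC)[C@@H](C)CC)C(C)(C)C)C(=O)NS(=O)(=O)C1CC1` gives 326 ug/mL and compound 1 `C=C[C@@H]1C[C@]1(NC(=O)[C@@H]1C[C@@H](Oc2nccc3cc(OC)ccc23)CN1C(=O)[C@@H](NC(=O)N[C@H](COC)C(C)C)C(C)(C)C)C(=O)NS(=O)(=O)C1CC1` gives 570 ug/mL as its value, which leaves a 1.7-fold lower number from compound 1 to compound 2 (0.24 log units; within the scatter) between the two. Compound 3 `C=C[C@@H]1C[C@]1(NC(=O)[C@@H]1C[C@@H](Oc2nccc3cc(OC)ccc23)CN1C(=O)[C@@H](NC(=O)N[C@H](C(=O)O)C(C)(C)C)C(C)(C)C)C(=O)NS(=O)(=O)C1CC1` reads > 1160 ug/mL as a limit of the assay, not a number.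

Compound 4 `C=C[C@@H]1C[C@]1(NC(=O)[C@@H]1C[C@@H](Oc2nccc3cc(OC)ccc23)CN1C(=O)[C@@H](NC(=O)N[C@H](C(N)=O)C(C)(C)C)C(C)(C)C)C(=O)NS(=O)(=O)C1CC1` is still unmeasured and carries 1-carbamoyl-2,2-dimethylpropyl in place of 1-(methoxymethyl)-2-methylbutyl on an amide-type nitrogen, counted as 1-carbamoyl-2,2-dimethylpropyl in place of 1-(methoxymethyl)-2-methylbutyl on an amide-type nitrogen for the difference from compound 2.

Going by the values given here, two measured steps bear on this change, both ending at compound 3 with 1-carboxy-2,2-dimethylpropyl on that nitrogen: an at least 3.5-fold higher number from compound 2 to compound 3 (0.55 log units; beyond the scatter) and an at least 2.0-fold higher number from compound 1 to compound 3 (0.30 log units; that floor lies within the scatter) are the two readings. Both point upward, but compound 3 is not compound 4, as 1-carboxy-2,2-dimethylpropyl differs from 1-carbamoyl-2,2-dimethylpropyl. Only a small upward move in this assay is therefore expected, possibly none beyond the scatter. The estimated step is a 1.2-fold higher number from compound 2 to compound 4 (0.09 log units; within the scatter) on this reasoning. For compound 4 the estimate is 400 ug/mL with an expected range of 130 ug/mL to 1100 ug/mL in this read-out.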

Compound 4, solubility: 557 ug/mL
Compound 4: the middle estimate sits 1.4-fold (0.14 log units) below what was measured; measured number inside the range.
By their numbers in this assay, from the lowest: compounds 2, 4 and 1 (each within the scatter of the next). At a limit, above all of these: compound 3.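

In this assay, 1-carbamoyl-2,2-dimethylpropyl on the amide-type nitrogen stays within the scatter of both chains carrying methoxymethyl: a 1.7-fold higher number from compound 2 to compound 4 (0.23 log units; within the scatter) and a 1.0-fold lower number from compound 1 to compound 4 (0.01 log units; within the scatter). Going by these compounds alone, the single change of amino in place of hydroxy on the carbonyl carbon gives a step beyond the scatter, so at this position the two carbonyl-bearing chains can be told apart, which the earlier compounds could not show: an at least 2.0-fold lower number from compound 3 to compound 4 (0.31 log units; beyond the scatter). That step is only a floor, since compound 3 stands at a limit of the assay: the limit of > 1160 ug/mL in this assay, at which 1 of the 4 values shown sits.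

Going by these compounds, the true distance between compound 3 and compound 4 remains open. Also open, on these data alone, is whether a methyl ester or a primary amine on the same 2,2-dimethylpropyl chain would read with compound 4 or with compound 3.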